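The compounds below may be only part of what the source reports. "The series", "measured", "known", "first", "only" and "open" are said of these compounds alone.

Measured compounds:
- compound 1, `O=C(Nc1ccc(Oc2ccnc3[nH]ccc23)cc1)c1cc2cccnc2n(-c2ccc(F)cc2)c1=O`: 190 nM
- compound 2, `Cn1ccc2c(Oc3ccc(NC(=O)c4cc5cccnc5n(-c5ccc(F)cc5)c4=O)cc3)ccnc21`: 260 nM
- compound 3, `Cn1ccc2c(Oc3ccc(NC(=O)c4cc5cccnc5n(-c5ccc(Cl)cc5)c4=O)cc3)ccnc21`: "not determined" (no result reported)

In a functional assay on NCI-H460 cells (Homo sapiens) for antiproliferative activity, read by MTT assay, with a stated time of 72 h (a lower number here means a stronger inhibitor, a higher number a weaker inhibitor), compound 1 gives 190 nM and compound 2 gives 260 nM. Compound 3 carries a chloro group on the pendant aryl ring in place of the fluoro of compound 2, and for it no number is reported. Of the two measured numbers, compound 2 holds the higher one, and its nearest neighbour is compound 1; the single shown step, a 1.4-fold higher number from compound 1 to compound 2 (0.14 log units; within the scatter), is a methyl in place of hydrogen on an aromatic nitrogen and stays within the scatter, so the two compounds cannot be ordered.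

Compound 4, `Cn1ccc2c(Oc3ccc(NC(=O)c4cc5cccnc5n(-c5ccc(F)cc5)c4=O)cc3F)ccnc21`, differs from compound 2 by fluoro in place of hydrogen on an aromatic carbon. Among the measured compounds shown here, no measured step touches this part of the shared core, so the only guidance is that the one change seen so far barely moved the read-out in this assay. With nothing pointing to a large shift in either direction, the expectation is a step of a 1.2-fold lower number from compound 2 to compound 4 (0.07 log units; within the scatter) that stays within the scatter. Compound 4 is therefore estimated at 220 nM, in a range from 80 nM to 600 nM.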

Compound 4, half-maximal inhibitory concentration: 250 nM
Compound 4: middle estimate off by 1.1-fold (0.06 log units), on the low side; the measured number falls inside the stated range.
By their numbers in this assay, from the lowest: compounds 1, 4 and 2 (each within the scatter of the next).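

In this assay, fluoro in place of hydrogen on an aromatic carbon, ortho to a large group and meta to a large group, gives a 1.0-fold lower number from compound 2 to compound 4 (0.02 log units; within the scatter), so this pair cannot be ordered. Among the compounds shown here, the only earlier step concerned an aromatic nitrogen, so this is the first reading from the six-membered aromatic ring of carbon only, and it shows that this position can carry a fluoro group with the read-out staying within the scatter. No measurement bearing on the reason for this result is available.

On these data alone, whether an amine, a methoxy group or a carboxylic acid on the same carbon would also stay within the scatter remains open, as does what fluoro would do on the other carbons of that ring. Also open, as far as these compounds go, is whether fluoro on this carbon would give the same picture with hydrogen rather than methyl on the aromatic nitrogen, as in compound 1.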